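The compounds below may be only part of what the source reports. "The series", "measured", "known", "first", "only" and "open" are said of these compounds alone.

In a functional assay on SK-OV-3 cells (Homo sapiens) for inhibition, read by CCK-8 assay, with a stated time of 70 h (a lower number here means a stronger inhibitor, a higher number a weaker inhibitor), compound 1 (`COc1ccc(OCCOCCNC2CCCC2)cc1`) gives 99100 nM, compound 2 (`Nc1ccccc1COc1ccc(OCCOCCNC2CCCC2)cc1`) gives 14000 nM and compound 3 (`O=Cc1ccc(COc2ccc(OCCOCCNC3CCCC3)cc2)cc1`) gives 45000 nM, the second highest of these numbers. Compound 4 (`O=C(O)c1ccc(COc2ccc(OCCOCCNC3CCCC3)cc2)cc1`) turns the formyl of compound 3 into carboxy, with hydroxy in place of hydrogen on a carbonyl carbon. Going by the values given here, no measured step changes that carbonyl carbon itself. The nearest guides are exchanges of whole groups on a saturated chain carbon bound to an oxygen on an aromatic ring, and they stayed modest: a 2.2-fold lower number from compound 1 to compound 3 (0.34 log units; beyond the scatter), and a 3.2-fold higher number from compound 2 to compound 3 (0.51 log units; beyond the scatter). A small change is therefore expected here, with the direction unsettled by the data and only a slight lean towards a higher number. The expected step is a 1.3-fold higher number from compound 3 to compound 4 (0.12 log units; within the scatter). For compound 4 the estimated value is 60000 nM, with an expected range of 20000 nM to 150000 nM.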

Compound 4, half-maximal inhibitory concentration: > 100000 nM
Compound 4: a limit, no number; the forecaster's own chance of this, stated with the estimate: 15%; middle value at least 1.6-fold (0.22 log units) from the limit.
By their numbers in this assay, from the lowest: compound 2; then compound 3; then compound 1. At a limit, above all of these: compound 4.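

For compound 4 the reading is a limit, not a number: the limit of > 100000 nM in this assay, at which 1 of the 4 values shown sits. Even so, a single added hydroxy on this carbonyl carbon moves the result clearly, giving an at least 2.2-fold higher number from compound 3 to compound 4 (0.34 log units; beyond the scatter), and exchanging the whole group gives an at least 7.1-fold higher number from compound 2 to compound 4 (0.85 log units; beyond the scatter), so this carbonyl carbon is not indifferent to change in this assay. Putting 4-carboxyphenyl in place of hydrogen gives a number no lower from compound 1 to compound 4 (the limit leaves the size open), and the size of this step cannot be read. The compounds shown leave open how far the true value of compound 4 lies past the limit. They also leave open how a methyl ester or an amide on this carbonyl carbon would read.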